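This account rests on a few compounds, and the source may have more. Where it says the series, first, only, none or still open, it means among the compounds named here.

Working notes on the series in a toxicity assay on MT4 cells (Homo sapiens) for cytotoxicity, read by MTT assay, with a stated time of 5 days; on this read-out higher numbers stand for lower toxicity in this test and lower numbers for higher toxicity in this test.

Of the compounds shown here, three have numbers so far. Compound 1 `Cc1cnc(Nc2ccc(C#N)cc2)nc1Nc1c(F)cc(-c2cccnc2)cc1F` gives 1100 nM. Compound 2 `Cc1cnc(Nc2ccc(C#N)cc2)nc1Nc1c(F)cc(-c2cncc(C#N)c2)cc1F` gives 50000 nM. Compound 3 `Cc1cc(-c2cccs2)cc(C)c1Nc1ccnc(Nc2ccc(C#N)cc2)n1` gives 10000 nM, which places compound 3 second highest of the three: its nearest neighbour is compound 2 with a higher number, and its furthest is compound 1 with a lower number, both gaps beyond the scatter.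

Among the compounds with values here, the only step between measured compounds that differ in one place is a 45-fold higher number from compound 1 to compound 2 (1.66 log units; beyond the scatter), a change on the biaryl ring of the shared core of compound 1.

Compound 4 `Cc1cc(-c2ccnc(F)c2)cc(C)c1Nc1ccnc(Nc2ccc(C#N)cc2)n1` is not yet measured. It differs from compound 3 at the same kind of position, the ring attached para to the large group: 2-fluoropyridin-4-yl in place of thiophen-2-yl on an aromatic carbon. The step from compound 1 to compound 2 is the only one that bears on it, and it was large, though the change there was a cyano for a hydrogen rather than one whole aromatic ring for another, so its direction rather than its size is taken as the guide. A moderate rise in this assay is therefore expected, a 1.8-fold higher number from compound 3 to compound 4 (0.26 log units; within the scatter), with a real chance of no step beyond the scatter.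

Compound 4 is expected at 18000 nM, within a range of 5000 nM to 60000 nM.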

Compound 4, half-maximal cytotoxic concentration: 6000 nM
The estimate for compound 4 lay 3.0-fold (0.48 log units) above the measured number; the measured number falls inside the stated range.
By their numbers in this assay, from the lowest: compound 1; then compounds 4 and 3 (each within the scatter of the next); then compound 2.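

In this assay, exchanging one whole aromatic ring for another on an aromatic carbon para to a large group and meta to two methyl groups gives a 1.7-fold lower number from compound 3 to compound 4 (0.22 log units; within the scatter), so thiophen-2-yl and 2-fluoropyridin-4-yl cannot be told apart at this place, although one is a five-membered and the other a six-membered aromatic ring. This shows that a change on this ring need not produce a large step, in contrast to a 45-fold higher number from compound 1 to compound 2 (1.66 log units; beyond the scatter), where cyano replaces hydrogen on an aromatic carbon of the ring at the same kind of place. No measurement here bears on why the ring exchange leaves the number within the scatter.

The compounds shown leave open whether a cyano group on the 2-fluoropyridin-4-yl ring of compound 4 would give a step as large as the one from hydrogen to cyano in the other pair. They also leave open how the number would respond if a non-aromatic group, such as an amine or a carboxylic acid, stood at this place instead of an aromatic ring.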